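The source may hold more compounds than are shown below. What is called first, only, known or untested is meant among the compounds shown, and "the series" means these compounds.

Measured so far in a functional assay on Huh-7 cells (Homo sapiens) for inhibition, read by MTT assay, with a stated time of 48 h; a lower number here means a stronger inhibitor, a higher number a weaker inhibitor: compound 1 `COc1ccc2c(=O)c(/C=C/C(=O)NCc3ccccc3)coc2c1` gives 13600 nM; compound 2 `COc1cccc(NC(=O)/C=C/c2coc3cc(OC)ccc3c2=O)c1` gives 11100 nM; compound 3 `COc1ccc2c(=O)c(/C=C/C(=O)Nc3ccccc3OC)coc2c1` gives 32300 nM.

Compound 3 carries the highest number of the three and is therefore the weakest inhibitor of this small set: the step of a 2.4-fold higher number from compound 1 to compound 3 (0.38 log units; beyond the scatter) and the step of a 2.9-fold higher number from compound 2 to compound 3 (0.46 log units; beyond the scatter) both lie beyond the scatter, whereas the step of a 1.2-fold lower number from compound 1 to compound 2 (0.09 log units; within the scatter) does not. Compound 4 `COc1ccc2c(=O)c(/C=C/C(=O)Nc3ccc(Cl)cc3)coc2c1` differs from compound 3 in one place: 4-chlorophenyl in place of 2-methoxyphenyl on an amide-type nitrogen. The two measured steps that bear on this change are the ones leading into the 2-methoxyphenyl group, and both raised the number modestly. Among the measured compounds shown here, the new step leads away from that group, into a 4-chlorophenyl that no measured compound carries, so its own effect is unknown. A modest fall of the number for compound 4 is therefore expected, a 2.3-fold lower number from compound 3 to compound 4 (0.36 log units; beyond the scatter), with a wide range to cover the untested group. Compound 4 is estimated at 14000 nM, between 6000 nM and 32000 nM.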

Compound 4, half-maximal inhibitory concentration: 37100 nM
Compound 4: middle estimate off by 2.7-fold (0.42 log units), on the low side; the whole stated range lies below it.
By their numbers in this assay, from the lowest: compounds 2 and 1 (each within the scatter of the next); then compounds 3 and 4 (each within the scatter of the next).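

In this assay, 4-chlorophenyl and 2-methoxyphenyl on the amide-type nitrogen cannot be told apart, a 1.1-fold higher number from compound 3 to compound 4 (0.06 log units; within the scatter), so two groups that differ in their substituent and its place on the ring give the same reading within the scatter. Compound 4 also stands apart from the other two compounds, a 3.3-fold higher number from compound 2 to compound 4 (0.52 log units; beyond the scatter) and a 2.7-fold higher number from compound 1 to compound 4 (0.44 log units; beyond the scatter), which shows that a substituted phenyl on this nitrogen does not by itself set the number, as the 3-methoxyphenyl of compound 2 goes against any such rule. Nothing available here accounts for these differences.

Still open, going by these compounds, is how a plain phenyl with no substituent, or a longer chain such as phenylethyl, would read on this nitrogen. Also open, on these data alone, is whether a ring carrying an amine or a carboxylic acid would fall with compound 2 or with compound 4.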